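Aryl substituent exchange on the shared core

The source may hold more compounds than are shown below. What is called first, only, known or untested is meant among the compounds shown, and "the series" means these compounds.

Compound 2 `CCCc1ccc(N2C(=O)NC3(CSC4=C3C(=O)c3ncccc3C4=O)C2=O)cc1` gives 1 nM in a functional assay on MT4 cells (Homo sapiens) for antiproliferative activity, read by MTT assay, with a stated time of 96 h (a higher number here means a weaker inhibitor, a lower number a stronger inhibitor), the lowest of the two values recorded. Within the data shown here, compound 1 `O=C1NN(c2ccc([N+](=O)[O-])cc2)C(=O)C2(CSC3=C2C(=O)c2ncccc2C3=O)N1` gives 5 nM in this assay, a gap beyond the scatter; no single step between these two is recorded. Compound 3 `CN(C)c1ccc(N2C(=O)NC3(CSC4=C3C(=O)c3ncccc3C4=O)C2=O)cc1` carries one change from compound 2: dimethylamino in place of propyl on an aromatic carbon. Among the measured compounds shown here, no measured pair shows this change, so nothing sets its size; a step of a 2.0-fold higher number from compound 2 to compound 3 (0.30 log units; within the scatter) is expected, none beyond the scatter. Compound 3 is estimated at 2 nM, with a range from 0.7 nM to 6 nM.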

Compound 3, half-maximal inhibitory concentration: 15 nM
Beside the measured number, compound 3's estimate is 7.5-fold (0.88 log units) below it; the whole stated range lies below it.
By their numbers in this assay, from the lowest: compound 2; then compound 1; then compound 3.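

On the aromatic carbon para to a large group, the series now has its first readable single change in this assay: swapping propyl for dimethylamino gives a 15-fold higher number from compound 2 to compound 3 (1.18 log units; beyond the scatter) with the heavy-atom count unchanged. This position therefore responds strongly to the identity of its substituent, and equal size in heavy atoms does not make two groups interchangeable here. Nothing available explains this step.

Open, from the compounds shown here alone, is where a longer alkyl chain, a methoxy group or a primary amine would fall at this position. Also open, going by these compounds, is whether the same exchange would give a similar step on the core of compound 1.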